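Swapping isopropyl for 2-hydroxyethyl on the weakest compound

The compounds below may be only part of what the source reports. "The series", "measured", "known", "first", "only" and "open" are said of these compounds alone.

- compound 1 `COc1cc(Sc2c[nH]c3ccc(Cl)cc23)cc(OC)c1OC`: 77 nM
- compound 2 `CCOc1ccc2[nH]cc(Sc3cc(OC)c(OC)c(OC)c3)c2c1`: 16 nM
- compound 3 `COc1cc(Sc2c[nH]c3ccc(OC(C)C)cc23)cc(OC)c1OC`: 1500 nM

These values come from a functional assay on MCF7 cells (Homo sapiens) for inhibition, with a stated time of 48 h; on this read-out higher numbers stand for weaker inhibition and lower numbers for stronger inhibition. Among the three, compound 3 has the highest number, and its steps to both others lie beyond the scatter, so it is the weakest inhibitor so far. Compound 4 `COc1cc(Sc2c[nH]c3ccc(OCCO)cc23)cc(OC)c1OC` keeps the shared core but carries 2-hydroxyethyl in place of isopropyl on an oxygen on an aromatic ring.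

Within the data shown here, two measured steps bear most directly on this change. Replacing chloro with isopropoxy gave a 19-fold higher number from compound 1 to compound 3 (1.29 log units; beyond the scatter), a large loss. Methyl in place of hydrogen on the ethoxy chain gave a 94-fold higher number from compound 2 to compound 3 (1.97 log units; beyond the scatter), also large. Replacing chloro with ethoxy instead gave a 4.8-fold lower number from compound 1 to compound 2 (0.68 log units; beyond the scatter), a modest gain. Compound 4 loses the isopropyl, so a large fall in the number seems likely, given that compound 2 gives 16 nM. Among the measured compounds shown here, no measured compound shows what the added hydroxyl does, so a full return to that level is not assumed. The expected change is a 7.5-fold lower number from compound 3 to compound 4 (0.88 log units; beyond the scatter). The estimate for compound 4 is 200 nM, with an expected range from 30 nM to 1200 nM.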

Compound 4, half-maximal inhibitory concentration: 95 nM
For compound 4 the middle estimate is 2.1-fold (0.32 log units) above the measured one, and the stated range covers the measured number.
By their numbers in this assay, from the lowest: compound 2; then compounds 1 and 4 (each within the scatter of the next); then compound 3.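

In this assay isopropyl and 2-hydroxyethyl match in heavy-atom count, yet swapping one for the other gives a 16-fold lower number from compound 3 to compound 4 (1.20 log units; beyond the scatter) and so that count alone does not set the number at this oxygen. Hydroxy added to the ethoxy chain gives a 5.9-fold higher number from compound 2 to compound 4 (0.77 log units; beyond the scatter) and so this chain does better without it. Set against chloro, 2-hydroxyethoxy gives a 1.2-fold higher number from compound 1 to compound 4 (0.09 log units; within the scatter) and the two groups cannot be told apart here.

On these data alone, what stays open is how an amine or a carboxylic acid at the end of the chain, or a longer chain carrying the hydroxy, would read out at this oxygen. Nothing shown gives a reason for these differences.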